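A few compounds are considered here, and "the series" means these few. Any claim that something is new, unique, unknown or untested is made for them only; others in the source may bear on it.

Working notes on the series.

Compound 1 `Cc1ccc(Nc2nc(C(F)(F)F)ccc2CNC(=O)C(C)c2ccc(NS(C)(=O)=O)c(F)c2)cc1C` is the anilino member of the set. In a functional assay on CHO-K1 cells for antagonist activity at transient receptor potential cation channel subfamily V member 1 (Homo sapiens), read by FLIPR (on this read-out lower numbers stand for stronger inhibition and higher numbers for weaker inhibition), compound 1 gives 39.3 nM, the highest of the two numbers recorded, with compound 2 `CC(C(=O)NCc1ccc(C(F)(F)F)nc1N1CCCCC1C)c1ccc(NS(C)(=O)=O)c(F)c1` as its nearest neighbour at 2.9 nM. A third member, compound 3 `CC(C(=O)NCc1ccc(C(F)(F)F)nc1N1CCC(O)CC1)c1ccc(NS(C)(=O)=O)c(F)c1`, is reported in this assay only as "not active" (no number reported), without a number.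

Compound 4 `COC1CCN(c2nc(C(F)(F)F)ccc2CNC(=O)C(C)c2ccc(NS(C)(=O)=O)c(F)c2)CC1` is not yet measured. It differs from compound 1 in one place: 4-methoxypiperidin-1-yl in place of (3,4-dimethylphenyl)amino on an aromatic carbon.

Among the compounds with values here, the one step that bears on this change is a 14-fold lower number from compound 1 to compound 2 (1.13 log units; beyond the scatter), a large gain on replacing the (3,4-dimethylphenyl)amino group with a saturated ring of the same size class. Compound 3 carries a saturated ring of the same kind but with a hydroxyl on it and is recorded as inactive, so an oxygen on that ring is not harmless in this read-out. The expected outcome for compound 4 therefore sits between these two anchors: an improvement over compound 1 is estimated, a 3.8-fold higher number from compound 1 to compound 4 (0.58 log units; beyond the scatter), but smaller than the step to compound 2, and the range is set wide because compound 3 gives "not active" (no number reported). Compound 4 is estimated at 150 nM in this assay, within 15 nM to 2500 nM.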

Compound 4, inhibition constant: 2.4 nM
Beside the measured number, compound 4's estimate is 63-fold (1.80 log units) above it, outside the stated range (below it).
By their numbers in this assay, from the lowest: compounds 4 and 2 (each within the scatter of the next); then compound 1.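

Replacing the (3,4-dimethylphenyl)amino group on this aromatic carbon, next to the ring nitrogen, brings a large gain in this assay even when the incoming ring carries an oxygen: a 16-fold lower number from compound 1 to compound 4 (1.21 log units; beyond the scatter), and the earlier gain with a purely hydrocarbon ring was a 14-fold lower number from compound 1 to compound 2 (1.13 log units; beyond the scatter). The two saturated groups cannot be separated at this position, with a 1.2-fold lower number from compound 2 to compound 4 (0.08 log units; within the scatter), so 4-methoxypiperidin-1-yl serves here as well as 2-methylpiperidin-1-yl. An oxygen on the piperidine ring is therefore not disqualifying in itself, and methoxy and hydroxyl part sharply on this read-out, since compound 4 has a number while compound 3 is recorded as "not active" (no number reported), and no measurement at hand explains that contrast or the gain over the anilino group.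

Open, as far as these compounds go, is how far the tolerance for substituents on the piperidine ring extends, for instance whether an ethoxy group follows methoxy or whether a primary amine or a carboxylic acid in that place behaves like hydroxyl. Also open, from the compounds shown here alone, is whether the ring itself is needed, which a morpholin-4-yl ring or an open-chain diethylamino group would test.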